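Fluoro for hydrogen on the thiophene-type ring of compound 3

A few compounds are considered here, and "the series" means these few. Any claim that something is new, unique, unknown or untested is made for them only; others in the source may bear on it.

Working notes on the series. In a functional assay on cells for agonist activity at Free fatty acid receptor 1 (Homo sapiens), read by FLIPR and calcium flux (a lower number here means that less compound is needed, a higher number that more compound is needed for the effect), compound 3 `CC#C[C@@H](Cc1nnn[nH]1)c1ccc(OCc2ccc3scc(-c4ccc(OCCOC)cc4C)c3c2)cc1` gives 9 nM, the lowest number of the three measured compounds. Compound 1 `CC#C[C@@H](Cc1nnn[nH]1)c1ccc(OCc2ccc3sc(F)c(-c4ccccc4C)c3c2)cc1` gives 15 nM in this assay, which lies within the scatter of compound 3. Within the data shown here, compound 2 `CC#C[C@@H](Cc1nnn[nH]1)c1ccc(OCc2ccc3sc(C)c(-c4ccc(OCCOC)cc4C)c3c2)cc1` gives 47 nM in this assay, beyond the scatter of compound 3; the single step of a 5.2-fold lower number from compound 2 to compound 3 (0.72 log units; beyond the scatter) removes a methyl from the same aromatic carbon that is varied here.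

Compound 4 `CC#C[C@@H](Cc1nnn[nH]1)c1ccc(OCc2ccc3sc(F)c(-c4ccc(OCCOC)cc4C)c3c2)cc1` differs from compound 3 by fluoro in place of hydrogen on an aromatic carbon. Among the measured compounds shown here, no measured step places fluoro against hydrogen at this carbon. The step from compound 2 to compound 3 shows that a methyl there raises the number; compound 1 carries fluoro at this carbon, though with a different aryl group, and its value sits within the scatter of compound 3. For compound 4 the expected step of a 1.6-fold higher number from compound 3 to compound 4 (0.19 log units; within the scatter) in this assay is therefore within the scatter or at most a small rise, given the value of compound 1 15 nM. Compound 4 is estimated at 14 nM, with a range from 6 nM to 40 nM.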

Compound 4, half-maximal effective concentration: 18 nM
The estimate for compound 4 lay 1.3-fold (0.11 log units) below the measured number; low and high end bracket the measured number.
By their numbers in this assay, from the lowest: compounds 3, 1 and 4 (each within the scatter of the next); then compound 2.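

In this assay, fluoro now has a direct comparison with hydrogen on this aromatic carbon next to the ring sulfur: a 2.0-fold higher number from compound 3 to compound 4 (0.30 log units; within the scatter), so the two cannot be told apart here. Fluoro against methyl gives a 2.6-fold lower number from compound 2 to compound 4 (0.42 log units; beyond the scatter), so among hydrogen, fluoro and methyl at this carbon, only methyl stands apart. With fluoro held fixed at this carbon, adding the 2-methoxyethoxy group gives a 1.2-fold higher number from compound 1 to compound 4 (0.08 log units; within the scatter), so that group makes no readable difference in this pair.

No measurement shown bears on the reason for these results.

Going by these compounds, whether chloro, a nitrile or an amine at this carbon would stay with hydrogen and fluoro or move the number as methyl does remains open. Also open, on these data alone, is whether a carboxylic acid or a longer chain in place of the 2-methoxyethoxy group would change the number.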